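This account rests on a few compounds, and the source may have more. Where it says the series, first, only, none or still open, it means among the compounds named here.

- Compound 1 `O=C(NCCCCN(c1ccc(F)cc1)c1ccc(F)cc1)Nc1ccc(Cl)cc1`: > 20000 nM (a limit of the assay, not a number)
- Compound 2 `O=C(NCCCCN(c1ccc(F)cc1)c1ccc(F)cc1)Nc1ccc(Cl)c(C(F)(F)F)c1`: 5040 nM

Among the compounds with values here, in a functional assay on MDA-MB-231 cells (Homo sapiens) for cytotoxicity, read by MTT assay, with a stated time of 48 h (on this read-out higher numbers stand for weaker inhibition and lower numbers for stronger inhibition), compound 2 gives 5040 nM, the only exact number so far. Compound 3 `Cc1ccc(NC(=O)NCCCCN(c2ccc(F)cc2)c2ccc(F)cc2)cc1C` carries 3,4-dimethylphenyl in place of 4-chloro-3-(trifluoromethyl)phenyl on an amide-type nitrogen. Within the data shown here, one measured step bears on this change: an at least 3.9-fold lower number from compound 1 to compound 2 (0.59 log units; beyond the scatter), where trifluoromethyl replaced hydrogen on an aromatic carbon. Compound 3 gives up that trifluoromethyl, so part of this gain is expected to be lost, though its methyl groups make the comparison imperfect. The expected change in this assay is a 2.4-fold higher number from compound 2 to compound 3 (0.38 log units; beyond the scatter), towards weaker inhibition. Compound 3 is estimated at 12000 nM, with an expected range of 5000 nM to 28000 nM.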

Compound 3, half-maximal inhibitory concentration: > 20000 nM
Compound 3 gave a limit, no number; the forecaster's own chance of this, stated with the estimate: 40%; middle value at least 1.6-fold (0.22 log units) from the limit.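

In this assay the change of aryl group on the amide-type nitrogen gives an at least 3.9-fold higher number from compound 2 to compound 3 (0.59 log units; beyond the scatter) and shows that 3,4-dimethylphenyl does not keep the activity seen with 4-chloro-3-(trifluoromethyl)phenyl. Of the three aryl groups shown, only 4-chloro-3-(trifluoromethyl)phenyl gives an exact number. The step from compound 1 to compound 3 cannot be read because both values are limits of the assay, not numbers: the limit of > 20000 nM in this assay, at which 2 of the 3 values shown sit.

From the compounds shown here alone, whether trifluoromethyl keeps this activity without the chlorine remains open. So does whether a nitrile in its place would give an exact number.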